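Amide-end variation in a sulfonamide series against secreted frizzled-related protein 1

A few compounds are considered here, and "the series" means these few. Any claim that something is new, unique, unknown or untested is made for them only; others in the source may bear on it.

Measured so far:
compound 1 `O=C(c1cccc(Cl)c1)N1CCC(NS(=O)(=O)c2cc(S(=O)(=O)c3ccccc3)ccc2C(F)(F)F)CC1`: 870 nM
compound 2 `O=S(=O)(NC1CCN(S(=O)(=O)c2cccc(-c3nnn[nH]3)c2)CC1)c1cc(S(=O)(=O)c2ccccc2)ccc1C(F)(F)F`: 1200 nM
compound 3 `CC(C)(C)OC(=O)N1CCC(C(=O)N2CCC(NS(=O)(=O)c3cc(S(=O)(=O)c4ccccc4)ccc3C(F)(F)F)CC2)CC1`: 420 nM

In an assay on U2OS cells for inhibition of secreted frizzled-related protein 1 (Homo sapiens), read by a luciferase reporter, with a stated time of 18 h (a lower number here means that less compound is needed, a higher number that more compound is needed for the effect), compound 1 gives 870 nM, the second highest of the three numbers; compound 2 sits within the scatter of it, while compound 3 lies beyond the scatter on the lower side. Compound 4 `CC(C)(C)OC(=O)N1CCC[C@@H]1C(=O)N1CCC(NS(=O)(=O)c2cc(S(=O)(=O)c3ccccc3)ccc2C(F)(F)F)CC1` is not yet measured. It differs from compound 1 in one place: 1-(tert-butoxycarbonyl)pyrrolidin-2-yl in place of 3-chlorophenyl on a carbonyl carbon. Among the compounds with values here, no pair measured so far differs in just one place, so the step is estimated from the compound that resembles compound 4 most on that side of the molecule: compound 3, which gives 420 nM. The step of a 1.8-fold lower number from compound 1 to compound 4 (0.26 log units; within the scatter) is expected to be a small lowering, near the edge of the scatter. Compound 4 is expected to give about 480 nM, within 200 nM to 1200 nM.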

Compound 4, half-maximal effective concentration: 210 nM
The estimate for compound 4 lay 2.3-fold (0.36 log units) above the measured number; measured number inside the range.
By their numbers in this assay, from the lowest: compounds 4 and 3 (each within the scatter of the next); then compounds 1 and 2 (each within the scatter of the next).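

Within the data shown here, on the carbonyl carbon whose other neighbours are an amide-type nitrogen in a ring, this is the first single-place change that can be read, and 1-(tert-butoxycarbonyl)pyrrolidin-2-yl in place of 3-chlorophenyl gives a 4.1-fold lower number from compound 1 to compound 4 (0.62 log units; beyond the scatter) in this assay. The position therefore responds to its substituent, and a six-membered aromatic ring is not required there for this read-out. No measurement at hand explains the step. Still open, going by these compounds, is whether the tert-butoxycarbonyl group or the five-membered ring accounts for it, and how a free secondary amine in that ring or the opposite stereocentre would read.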